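This account rests on a few compounds, and the source may have more. Where it says the series, first, only, none or still open, it means among the compounds named here.

Measured so far in an assay on isolated protein for inhibition of Phenylethanolamine N-methyltransferase (Bos taurus); on this read-out higher numbers stand for weaker inhibition and lower numbers for stronger inhibition:

- compound 1, `CCCCCC(C#N)O[Si](C)(C)C`: 314000 nM
- compound 2, `CCCCCC(C)(C#N)O[Si](C)(C)C`: 669000 nM
- compound 3, `CCCCCC(C)(O)CN`: 669000 nM

Compound 1 and compound 2 differ in one place: methyl in place of hydrogen on a saturated chain carbon bound to an oxygen on an unsaturated carbon, a saturated chain carbon and a triple-bonded carbon. That change gave a 2.1-fold higher number from compound 1 to compound 2 (0.33 log units; beyond the scatter), a modest shift toward weaker inhibition. Compound 3 stands level with compound 2 at the digits shown, and together they give the highest numbers of the three; against compound 1 it shows a difference of the same size as the step from compound 1 to compound 2, though no single counted difference separates compound 3 from compound 1, and the difference between the two cores is not broken down here.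

Compound 4, `CCCCCCC(C)(O)CN`, is not yet measured. It differs from compound 3 by methyl in place of hydrogen on a saturated chain carbon, six bonds along the chain from an oxygen on a saturated carbon. Among the compounds with values here, this is the same kind of change as the one from compound 1 to compound 2, but the place differs: there the methyl entered on a saturated chain carbon bound to an oxygen on an unsaturated carbon, a saturated chain carbon and a triple-bonded carbon, whereas here it enters on a saturated chain carbon six bonds along the chain from an oxygen on a saturated carbon. Within the data shown here, only one measured example of this kind of change exists, and it sits on a different core at a different place, so the expectation rests weakly on it.

For compound 4 a step of a 1.3-fold higher number from compound 3 to compound 4 (0.13 log units; within the scatter) is expected in this assay, because compound 3 already gives 669000 nM and the earlier step of a 2.1-fold higher number from compound 1 to compound 2 (0.33 log units; beyond the scatter) was modest and toward weaker inhibition. Compound 4 is estimated at 900000 nM, with a range from 400000 nM to 2500000 nM.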

Compound 4, half-maximal inhibitory concentration: 664000 nM
Beside the measured number, compound 4's estimate is 1.4-fold (0.13 log units) above it; low and high end bracket the measured number.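

In this assay, methyl in place of hydrogen on a saturated chain carbon, six bonds along the chain from an oxygen on a saturated carbon, gives a 1.0-fold lower number from compound 3 to compound 4 (0.00 log units; within the scatter). Set beside the earlier methyl-for-hydrogen step, the result gives no sign that the change reads differently on the two cores: the same change on two cores in this assay, a 2.1-fold higher number (0.33 log units; beyond the scatter) from compound 1 to compound 2 and a 1.0-fold lower number (0.00 log units; within the scatter) from compound 3 to compound 4, 2.1-fold (0.33 log units) apart, within the scatter of two such steps. This is not proof that the change carries from one core to the other: the methyl enters at a different place on each core, each core offers a single pair, and one step lies beyond the scatter while the other lies within it.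

Open, from the compounds shown here alone, is whether a longer chain, such as ethyl or propyl in place of that methyl, would read differently from the methyl on the core of compound 3. Also open, going by these compounds, are how a carboxylic acid in place of the nitrile would read on the core of compound 1, and whether the methyl change entering at one matching place would give matching steps on both cores.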